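The source may report more compounds than this note shows. Statements on the series, on what has been measured and on what is new or still open speak of the compounds shown alone.

Working notes on the series, all read in a functional assay on MDA-MB-435S cells (Homo sapiens) for cytotoxicity, read by MTT assay (a lower number here means a stronger inhibitor, a higher number a weaker inhibitor), for now. Compound 1 (`COc1ccc(-c2oc3c(CC=C(C)C)c(OC(C(=O)O)C(=O)O)cc(O)c3c(=O)c2OC(C(=O)O)C(=O)O)cc1`) gives 78900 nM there. Compound 2 (`CCOC(=O)C(C)Oc1cc(O)c2c(=O)c(O)c(-c3ccc(OC)cc3)oc2c1CC=C(C)C`) gives 2500 nM as the lower of the two numbers, a gap beyond the scatter. Compound 3 (`COc1ccc(-c2oc3c(CC=C(C)C)c(OC(C)C(=O)O)cc(O)c3c(=O)c2O)cc1`) has hydrogen in place of ethyl on an oxygen next to a carbonyl group, turning ethoxycarbonyl to carboxy. Among the compounds with values here, compound 1, which also carries carboxy groups but differs in more places, sits at 78900 nM as the only guide, so a step to a higher number, beyond the scatter, is expected. The expected move is an estimated 6.0-fold higher number from compound 2 to compound 3 (0.78 log units; beyond the scatter) in this series. For compound 3 the estimate is 15000 nM with an expected range from 5000 nM to 50000 nM at the upper end.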

Compound 3, half-maximal inhibitory concentration: 5700 nM
Compound 3: middle estimate off by 2.6-fold (0.42 log units), on the high side; low and high end bracket the measured number.
By their numbers in this assay, from the lowest: compound 2; then compound 3; then compound 1.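

In this assay, the change from ethoxycarbonyl to carboxy can now be read on its own (a 2.3-fold higher number from compound 2 to compound 3 (0.36 log units; beyond the scatter)), a modest step with the rest of the molecule unchanged. Compound 3 still gives 5700 nM without the ethyl, so the ethyl ester is not required for a number of this order at this position. No data on hand account for the step. Still open, going by these compounds, is how a primary amide or a butyl ester would read at this carbonyl group. Also open, on these data alone, is whether the step holds when the other groups on the shared core change.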